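Growth inhibition notes: bromo in place of methoxy

The source may hold more compounds than are shown below. What is called first, only, known or untested is meant among the compounds shown, and "the series" means these compounds.

Measured in a functional assay on U-251 cells (Homo sapiens) for inhibition, read by sulforhodamine B assay, with a stated time of 48 h; on this read-out higher numbers stand for weaker inhibition of growth and lower numbers for stronger inhibition of growth:
compound 1 `S=C(N/N=C/c1cccs1)Nc1ccccc1`: 74700 nM
compound 2 `Cc1ccc(NC(=S)N/N=C/c2cccs2)cc1`: 12600 nM
compound 3 `COc1ccc(NC(=S)N/N=C/c2cccs2)cc1`: > 100000 nM, a limit

Compound 3 stands at > 100000 nM, which is a limit and not a number. Compound 4 `S=C(N/N=C/c1cccs1)Nc1ccc(Br)cc1` carries bromo in place of methoxy on an aromatic carbon. Among the compounds with values here, no measured compound carries bromo, so the support is indirect. Methyl in place of hydrogen gave a 5.9-fold lower number from compound 1 to compound 2 (0.77 log units; beyond the scatter). Methoxy in place of hydrogen gave an at least 1.3-fold higher number from compound 1 to compound 3 (0.12 log units; that floor lies within the scatter). Methoxy in place of methyl gave an at least 7.9-fold higher number from compound 2 to compound 3 (0.89 log units; beyond the scatter), the step closest to this change, since methoxy also leaves here. A move of modest size towards a lower number in this assay is therefore expected, though the size remains uncertain. The expected step is an at least 4.0-fold lower number from compound 3 to compound 4 (0.60 log units; beyond the scatter). For compound 4 the estimated value is 25000 nM, with an expected range of 6000 nM to 90000 nM.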

Compound 4, concentration for 50% growth inhibition: 4200 nM
Estimate against measurement, compound 4: 6.0-fold (0.77 log units) above; measured number outside the range, below it.
By their numbers in this assay, from the lowest: compound 4; then compound 2; then compound 1. At a limit, above all of these: compound 3.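

In this assay, bromo takes this position well past what methyl reached: there is an 18-fold lower number from compound 1 to compound 4 (1.25 log units; beyond the scatter) and then a 3.0-fold lower number from compound 2 to compound 4 (0.48 log units; beyond the scatter), so the change from hydrogen is now large rather than modest. Methyl in compound 2 and bromo in compound 4 both lower the number from compound 1, while methoxy in compound 3 goes against that pattern, and the swap of methoxy for bromo gives an at least 23-fold lower number from compound 3 to compound 4 (1.37 log units; beyond the scatter), which is a floor and not a full size. Compound 3 stands at a limit and not a number: the limit of > 100000 nM in this assay, at which 1 of the 4 values shown sits.

As far as these compounds go, whether chloro, an amine or a carboxylic acid at this place would side with bromo or with methoxy stays open. What separates methoxy from methyl and bromo also stays open, as the compounds shown give no measured property that bears on it.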